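Methyl for hydrogen on the pyridine-type ring of the shared core

A few compounds are considered here, and "the series" means these few. Any claim that something is new, unique, unknown or untested is made for them only; others in the source may bear on it.

Three compounds of the series have been run in an ADME assay on cells (Hepatocyte, Rattus norvegicus) for metabolic stability, using equilibrium dialysis; a higher number here means faster removal of the compound, a lower number slower removal. Compound 1 `CC(=O)N[C@@H]1CCC[C@H](C(=O)Nc2cc(-c3cnn4c3CN(C)CC4)c(Cl)cn2)C1` gives 7.7 uL/min. Compound 2 `CC(=O)N[C@@H]1CCC[C@H](C(=O)Nc2cc(-c3cnn4c3CC(C)(C)CC4)c(F)cn2)C1` gives 42 uL/min. Compound 3 `CC(=O)N[C@@H]1CCC[C@H](C(=O)Nc2cc(-c3cnn4c3CC(C)(C)C4)ccn2)C1` gives 45 uL/min; its number sits within the scatter of the number of compound 2 and well beyond the scatter above the number of compound 1, which is the only clear separation among the three.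

Compound 4 `CC(=O)N[C@@H]1CCC[C@H](C(=O)Nc2cc(-c3cnn4c3CC(C)(C)C4)c(C)cn2)C1` is not yet measured. It differs from compound 3 in one place: methyl in place of hydrogen on an aromatic carbon. Going by the values given here, no measured pair shows this particular exchange, so there is no step on which to rest a direction; the numbers of compound 2 and compound 3 only show that the neighbouring positions of the core tolerate small changes without a shift beyond the scatter.

The expectation for compound 4 is therefore no step beyond the scatter from compound 3, a 1.1-fold higher number from compound 3 to compound 4 (0.05 log units; within the scatter), with the estimate for compound 4 in this assay at 50 uL/min, between 25 uL/min and 100 uL/min.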

Compound 4, intrinsic clearance in a liver preparation (reported as CLH), per the amount of preparation that the assay uses in the Hepatocyte assay: 53 uL/min
Estimate against measurement, compound 4: 1.1-fold (0.03 log units) below; the range from low to high includes it.
By their numbers in the Hepatocyte assay, from the lowest: compound 1; then compounds 2, 3 and 4 (each within the scatter of the next).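

In the Hepatocyte assay methyl in place of hydrogen on an aromatic carbon, ortho to a large group and two atoms from the ring nitrogen, gives a 1.2-fold higher number from compound 3 to compound 4 (0.07 log units; within the scatter) and so this carbon takes the added methyl without a shift that repeat measurements could separate. In a physicochemical assay for lipophilicity, using the shake flask method, measured as octanol-water partition, at pH 7.4 (a lower number here means a more polar compound, a higher number a more lipophilic compound), compound 3 gives 2.8 and compound 4 gives 3.1 that is a number 0.30 log units higher from compound 3 to compound 4 (within the scatter) and so neither read-out separates the pair. Going by these compounds alone, the earlier compounds differ from one another in more than one place, which makes this the first reading of a single exchange at this carbon.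

From the compounds shown here alone, whether an amine or a longer chain on the same carbon would also stay within the scatter in the Hepatocyte assay remains open. Nothing at hand accounts for these numbers.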